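The compounds below may be only part of what the source reports. "The series", "measured", "known", "first", "only" and "open" are said of these compounds alone.

Measured so far:
compound 1, `O=C1/C(=C/c2cccc([N+](=O)[O-])c2)CN(S(=O)(=O)c2ccc(F)cc2)C/C1=C\c1cccc([N+](=O)[O-])c1`: 11900 nM
compound 2, `N#Cc1ccc(/C=C2\CN(S(=O)(=O)c3ccc(F)cc3)C/C(=C\c3ccc(C#N)cc3)C2=O)cc1`: 11300 nM
compound 3, `CC(=O)Nc1ccc(S(=O)(=O)N2C/C(=C\c3cccc([N+](=O)[O-])c3)C(=O)/C(=C/c3cccc([N+](=O)[O-])c3)C2)cc1`: 6760 nM

Of the compounds shown here, three have been tested in a functional assay on QGY-7703 cells (Homo sapiens) for cytotoxicity, read by MTT assay, with a stated time of 24 h; on this read-out lower numbers stand for stronger inhibition and higher numbers for weaker inhibition. In this assay compound 1 gives 11900 nM and compound 2 gives 11300 nM; the two values lie within the scatter of each other. Compound 3 differs from compound 1 in one place, (acetamido in place of fluoro on an aromatic carbon), and the change made a 1.8-fold lower number from compound 1 to compound 3 (0.25 log units; within the scatter). The difference between the core of compound 1 and the core of compound 2 is not broken down here.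

Compound 4, `CC(=O)Nc1ccc(S(=O)(=O)N2C/C(=C\c3ccc(C#N)cc3)C(=O)/C(=C/c3ccc(C#N)cc3)C2)cc1`, has not yet been measured in this assay. It differs from compound 2 as acetamido in place of fluoro on an aromatic carbon, the same change as that from compound 1 to compound 3, at a place described in the same words. Because the change gave a 1.8-fold lower number from compound 1 to compound 3 (0.25 log units; within the scatter), compound 4 is expected to lie close to compound 2, with the step from compound 2 to compound 4 estimated as a 1.7-fold lower number from compound 2 to compound 4 (0.24 log units; within the scatter). The value of compound 4 in this assay is estimated at 6500 nM, most likely between 3000 nM and 14000 nM.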

Compound 4, half-maximal inhibitory concentration: 3320 nM
For compound 4 the middle estimate is 2.0-fold (0.29 log units) above the measured one, within the range that was stated.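

In this assay, acetamido in place of fluoro on an aromatic carbon gave a 3.4-fold lower number from compound 2 to compound 4 (0.53 log units; beyond the scatter), so on the core of compound 2 the change moved the number in the same direction as it did on the core of compound 1. Among these compounds, the two steps agree within what repeated measurements allow, so the change carried across these two cores without a detectable difference in size: the same change on two cores in this assay, a 1.8-fold lower number (0.25 log units; within the scatter) from compound 1 to compound 3 and a 3.4-fold lower number (0.53 log units; beyond the scatter) from compound 2 to compound 4, 1.9-fold (0.29 log units) apart, within the scatter of two such steps This rests on a single pair on each of only two cores, and it neither shows that the change would carry to any further core nor explains why the number falls, and only the step on the core of compound 2 lies beyond the scatter.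

The compounds shown leave open how an amine or a carboxylic acid would compare with acetamido at the same place on the ring. Also open, on these data alone, is whether the change from 4-fluorophenyl to 4-acetamidophenyl would act alike on a core carrying trifluoromethyl groups instead of the nitro or nitrile groups.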